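Swapping a bromo for a methoxy on the pendant ring

This account rests on a few compounds, and the source may have more. Where it says the series, first, only, none or still open, it means among the compounds named here.

Two compounds share one core and differ only in the ring carried on an aromatic nitrogen. Compound 1 `CCCNC(=O)c1cc(Oc2ccc(NC(=O)c3cc4cccnc4n(-c4ccccc4F)c3=O)cc2)ccn1` gives 390 nM in a functional assay on NCI-H460 cells (Homo sapiens) for antiproliferative activity, read by MTT assay, with a stated time of 72 h; on this read-out lower numbers stand for stronger inhibition and higher numbers for weaker inhibition. Among the measured compounds shown here, compound 2 `CCCNC(=O)c1cc(Oc2ccc(NC(=O)c3cc4cccnc4n(-c4ccc(Br)cc4)c3=O)cc2)ccn1` gives 620 nM in this assay, the higher of the two numbers, with compound 1 its only neighbour at a distance the data call within the scatter; the step of a 1.6-fold higher number from compound 1 to compound 2 (0.20 log units; within the scatter) was small. Compound 3 `CCCNC(=O)c1cc(Oc2ccc(NC(=O)c3cc4cccnc4n(-c4ccc(OC)cc4)c3=O)cc2)ccn1` has not been measured. It differs from compound 2 by methoxy in place of bromo on an aromatic carbon. For the measured compounds named here, the only measured step bearing on this is the ring swap from compound 1 to compound 2, which stayed within the scatter, so a change on this ring is expected to move the number little. Compound 3 is therefore expected to sit close to compound 2, with an expected step of a 1.1-fold lower number from compound 2 to compound 3 (0.05 log units; within the scatter), giving an estimate of 550 nM in this assay, in a range from 200 nM to 1500 nM.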

Compound 3, half-maximal inhibitory concentration: 1730 nM
Estimate against measurement, compound 3: 3.1-fold (0.50 log units) below; measured number above the stated range.
By their numbers in this assay, from the lowest: compounds 1 and 2 (each within the scatter of the next); then compound 3.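

In this assay, the pendant ring turns out to be sensitive to what it carries: methoxy in place of bromo on this aromatic carbon, para to a large group, gives a 2.8-fold higher number from compound 2 to compound 3 (0.45 log units; beyond the scatter), a step beyond the scatter, whereas the earlier ring swap stayed within it. Against the 2-fluorophenyl ring, the 4-methoxyphenyl ring gives a 4.4-fold higher number from compound 1 to compound 3 (0.65 log units; beyond the scatter), so compound 3 inhibits less strongly than either earlier compound, though both steps are modest. No measurement at hand accounts for this loss.

The compounds shown leave open whether other groups at this position, such as an amine or a hydroxyl, would sit nearer compound 2 or compound 3. They also leave open whether a longer chain such as ethoxy would move the number further than methoxy does.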